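Aryl ether substituent swap: compound 3 to compound 4

The source may hold more compounds than are shown below. What is called first, only, known or untested is meant among the compounds shown, and "the series" means these compounds.

Compound 3 `Cc1ccc(Oc2c(/C=N\OCc3c(Cl)c(-c4ccc(F)cc4)nn3C)c(C)nn2C)cc1` gives 5230 nM in a functional assay on SMMC-7721 cells (Homo sapiens) for antiproliferative activity, read by MTT assay, with a stated time of 72 h; a higher number here means a weaker inhibitor, a lower number a stronger inhibitor. Compound 1 `Cc1nn(C)c(Oc2ccc(F)cc2)c1/C=N\OCc1c(Cl)c(-c2ccc(F)cc2)nn1C` gives 6640 nM and compound 2 `Cc1nn(C)c(Oc2ccc(Cl)cc2)c1/C=N\OCc1c(Cl)c(-c2ccc(F)cc2)nn1C` gives 7970 nM; compound 3 shows the smallest of the three numbers, yet the steps of a 1.3-fold lower number from compound 1 to compound 3 (0.10 log units; within the scatter), a 1.5-fold lower number from compound 2 to compound 3 (0.18 log units; within the scatter) and a 1.2-fold higher number from compound 1 to compound 2 (0.08 log units; within the scatter) all lie within the scatter, so the three compounds cannot be separated. Compound 4 `COc1ccc(Oc2c(/C=N\OCc3c(Cl)c(-c4ccc(F)cc4)nn3C)c(C)nn2C)cc1` carries methoxy in place of methyl on an aromatic carbon. The three measured steps each exchange one group on an aromatic carbon, and none moved the number beyond the scatter; the change to compound 4 is of the same kind. No step beyond the scatter is therefore expected for compound 4, and a 1.1-fold higher number from compound 3 to compound 4 (0.02 log units; within the scatter) is the expected outcome. Compound 4 is estimated at 5500 nM, between 2700 nM and 11000 nM.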

Compound 4, half-maximal inhibitory concentration: 2050 nM
The estimate for compound 4 lay 2.7-fold (0.43 log units) above the measured number, and the stated range ends above it.
By their numbers in this assay, from the lowest: compound 4; then compounds 3, 1 and 2 (each within the scatter of the next).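

In this assay the group on this aromatic carbon of the aryl ether does matter: methoxy gives a 2.6-fold lower number from compound 3 to compound 4 (0.41 log units; beyond the scatter) and a 3.2-fold lower number from compound 1 to compound 4 (0.51 log units; beyond the scatter) and also a 3.9-fold lower number from compound 2 to compound 4 (0.59 log units; beyond the scatter) in modest steps. Fluoro, chloro and methyl stay within the scatter of one another, so among these four groups only methoxy stands apart. Nothing available accounts for this separation.

Going by these compounds, whether an ethoxy group or a hydroxyl group on the same carbon would follow methoxy remains open. So does the outcome with a dimethylamino group there.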